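A few compounds are considered here, and "the series" means these few. Any claim that something is new, unique, unknown or untested is made for them only; others in the source may bear on it.

Measured so far in a functional assay on DU-145 cells (Homo sapiens) for cytotoxicity, read by MTT assay, with a stated time of 48 h; on this read-out higher numbers stand for weaker inhibition and lower numbers for stronger inhibition:
- compound 1 `COc1ccc(/C=C/C(=O)/C=C/c2cc3ccccc3nc2Oc2ccccc2)cc1OC`: > 10000 nM, a limit
- compound 2 `COc1ccc(/C=C/C(=O)/C=C/c2cc3ccccc3nc2Oc2cccc(Cl)c2)c(OC)c1`: > 10000 nM, a limit
- compound 3 `COc1ccc(OC)c(/C=C/C(=O)/C=C/c2cc3ccccc3nc2Oc2cccc(Cl)c2)c1`: > 10000 nM, a limit

Compound 3 has no numerical value, only the limit > 10000 nM. It therefore cannot be ranked against the other two compounds, and the series as a whole offers no number to work from: the limit of > 10000 nM in this assay, at which 3 of the 3 values shown sit.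

Compound 4 `COc1ccc(/C=C/C(=O)/C=C/c2cc3ccccc3nc2Oc2cccc(Cl)c2)cc1OC` is reached from compound 3 by one change, (3,4-dimethoxyphenyl in place of 2,5-dimethoxyphenyl on a double-bonded chain carbon bound to a double-bonded chain carbon). In words, this is 3,4-dimethoxyphenyl in place of 2,5-dimethoxyphenyl on a double-bonded chain carbon bound to a double-bonded chain carbon.

For the measured compounds named here, the one measured step of a similar kind is a step that the two limits leave unreadable from compound 2 to compound 3. Both of its ends are limits, so it gives no size and no direction for the present change. On this evidence, no shift beyond the scatter can be forecast in this assay, and the most likely report for compound 4 is another limit. The expected size is given by a number no higher from compound 3 to compound 4 (the limit leaves the size open), with no direction favoured. For compound 4, the estimated value is 10000 nM, with an expected range of 3000 nM to 30000 nM.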

Compound 4, half-maximal inhibitory concentration: > 10000 nM
Compound 4: a limit, no number; the forecaster's own chance of this, stated with the estimate: 65%; the middle value sits exactly at the limit.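

No step to compound 4 can be read from compound 1, compound 2 or compound 3, as each pair ends in limits: the limit of > 10000 nM in this assay, at which 4 of the 4 values shown sit.

The compounds shown leave open whether 2,4-dimethoxyphenyl, 2,5-dimethoxyphenyl and 3,4-dimethoxyphenyl differ from one another in this assay, and whether chloro in place of hydrogen on an aromatic carbon changes the read-out at all.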